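Shifting a Trifluoromethyl Substituent Across Two Related Cores

A few compounds are considered here, and "the series" means these few. Any claim that something is new, unique, unknown or untested is made for them only; others in the source may bear on it.

Compound 1 `Oc1cccc(-c2cc(-c3cccc(C(F)(F)F)c3)cc(-c3cccc(O)c3)n2)c1` was tested in a functional assay on HCT-15 cells (Homo sapiens) for inhibition (on this read-out lower numbers stand for stronger inhibition and higher numbers for weaker inhibition), where compound 1 gives 13600 nM. Compound 2 `Oc1cccc(-c2cc(-c3ccc(C(F)(F)F)cc3)cc(-c3cccc(O)c3)n2)c1` carries 4-(trifluoromethyl)phenyl in place of 3-(trifluoromethyl)phenyl on an aromatic carbon. In this assay compound 2 reaches only the limit of > 50000 nM. That change produced an at least 3.6-fold higher number from compound 1 to compound 2 (0.56 log units; beyond the scatter). Compound 3 `Oc1ccc(-c2cc(-c3cccc(C(F)(F)F)c3)cc(-c3ccc(O)cc3)n2)cc1` differs from compound 1 in its core, a difference that is not broken down here. In this assay compound 3 sits at the limit of > 50000 nM. Compound 4 `Oc1ccc(-c2cc(-c3ccc(C(F)(F)F)cc3)cc(-c3ccc(O)cc3)n2)cc1` relates to compound 3 as compound 2 relates to compound 1, through (4-(trifluoromethyl)phenyl in place of 3-(trifluoromethyl)phenyl on an aromatic carbon), the same kind of change, here meta to two 4-hydroxyphenyl groups rather than meta to two 3-hydroxyphenyl groups. Compound 3 already rests at the limit of > 50000 nM in this assay, at which 2 of the 3 values shown sit. Compound 4 is expected to remain there as well, the step being estimated as a step that the limit leaves unreadable from compound 3 to compound 4. Compound 4 is therefore estimated at 100000 nM, with an expected range from 50000 nM to 300000 nM.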

Compound 4, half-maximal inhibitory concentration: > 50000 nM
Compound 4 gave a limit, no number; the forecaster's own chance of this, stated with the estimate: 90%; the middle value does not contradict the limit.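

Among these compounds, compound 3 and compound 4 both give only a limit, so no step between them can be read: the limit of > 50000 nM in this assay, at which 3 of the 4 values shown sit. The compounds shown leave open whether 4-(trifluoromethyl)phenyl in place of 3-(trifluoromethyl)phenyl changes inhibition at all on the core of compound 3.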